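The source may report more compounds than this note shows. Statements on the series, on what has been measured and on what is new or still open speak of the compounds shown alone.

Compound 1 `COc1ccc(/C=C/c2cc(/C=C/c3ccc(OC)c(OC)c3)nc(OCCCCCCBr)n2)cc1OC` was examined in a functional assay on HCT-116 cells (Homo sapiens) for cytotoxicity, read by fluorescence and resazurin assay, with a stated time of 48 h; a higher number here means a weaker inhibitor, a lower number a stronger inhibitor. In this assay compound 1 returns only a limit, > 20000 nM, and not a number. A second compound, compound 2 `BrCCCCOc1nc(/C=C/c2ccccc2)cc(/C=C/c2ccccc2)n1`, was measured alongside it; in this assay compound 2 also returns only a limit, > 20000 nM. Both measured values thus sit at the limit of > 20000 nM in this assay, at which 2 of the 2 values shown sit, so compound 1 stands level with everything else measured and no finite value sets it apart. Compound 3 `COc1ccc(/C=C/c2cc(/C=C/c3ccc(OC)c(OC)c3)nc(OCCCCBr)n2)cc1OC` has not yet been measured; it differs from compound 1 by bromo in place of 2-bromoethyl on a saturated chain carbon, four bonds along the chain from an oxygen on an aromatic ring. For the measured compounds named here, no step between measured compounds is known for a change of this kind, and nothing measured gives a finite potency from which a shift could be read. The step that the limit leaves unreadable from compound 1 to compound 3 is therefore expected to be none beyond the scatter, with compound 3 expected to stay at the limit. Compound 3 is estimated at 30000 nM in this assay, within a range from 15000 nM to 80000 nM.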

Compound 3, half-maximal inhibitory concentration: > 20000 nM
Compound 3: no number, only a limit; the forecaster's own chance of this, stated with the estimate: 85%; the middle value lies beyond the limit too.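

Compound 3 returns only a limit in this assay, as compound 1 does, so no new step can be read from compound 1 to compound 3: the limit of > 20000 nM in this assay, at which 3 of the 3 values shown sit.

With no finite value among the compounds shown, what bromo in place of 2-bromoethyl does to potency in this assay remains open.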